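Replacing 4-Methoxyphenyl with 3-Methylpyridin-2-yl

The source may report more compounds than this note shows. Statements on the series, on what has been measured and on what is new or still open speak of the compounds shown alone.

Compound 1 `N#Cc1ccccc1-c1cnc(C(=O)CCCCCCc2ccccc2)o1`: in an assay (Rattus norvegicus) for inhibition of Fatty-acid amide hydrolase 1 (Homo sapiens) (on this read-out higher numbers stand for weaker inhibition and lower numbers for stronger inhibition), compound 1 gives 130 nM.
Compound 2 `COc1ccc(-c2cnc(C(=O)CCCCCCc3ccccc3)o2)cc1`: in this assay compound 2 gives 100 nM.

Both compounds share the same core, carrying a ketone with a long chain that ends in a phenyl ring, and differ only in the aromatic group attached to the core. Compound 2 stands at the lower of the two numbers, but the step of a 1.3-fold lower number from compound 1 to compound 2 (0.11 log units; within the scatter) is within the scatter, so no order between the two can be claimed.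

Compound 3 `Cc1cccnc1-c1cnc(C(=O)CCCCCCc2ccccc2)o1` has not yet been measured. It differs from compound 2 in one place: 3-methylpyridin-2-yl in place of 4-methoxyphenyl on an aromatic carbon. Among the compounds with values here, the only measured step that bears on this position, a 1.3-fold lower number from compound 1 to compound 2 (0.11 log units; within the scatter), showed that exchanging one six-membered aromatic group for another left the number essentially unchanged. Resting on that single comparison, no step beyond the scatter is expected in this assay for compound 3. Compound 3 is therefore estimated at 110 nM, with a range from 40 nM to 350 nM. This estimate means an expected step of a 1.1-fold higher number from compound 2 to compound 3 (0.04 log units; within the scatter), which is expected to stay within the scatter.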

Compound 3, inhibition constant: 15 nM
For compound 3 the middle estimate is 7.3-fold (0.87 log units) above the measured one; measured number below the stated range.
By their numbers in this assay, from the lowest: compound 3; then compounds 2 and 1 (each within the scatter of the next).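

In this assay the move to 3-methylpyridin-2-yl gives a 6.7-fold lower number from compound 2 to compound 3 (0.82 log units; beyond the scatter) when 4-methoxyphenyl leaves and an 8.7-fold lower number from compound 1 to compound 3 (0.94 log units; beyond the scatter) when 2-cyanophenyl leaves. The two earlier compounds sat within the scatter of each other and gave no sign of any effect, whereas this result shows that the choice of six-membered aromatic group on this carbon of the five-membered ring, next to the ring oxygen, can change the number beyond the scatter. No measurement shown here explains why this group gives the lower number.

The new group differs from the other two in having a nitrogen in its ring and in carrying a methyl, and the compounds shown cannot tell which of these features matters, or whether both are needed. A plain pyridine ring without the methyl and a methylphenyl group without the ring nitrogen would pull the two features apart, while a group such as an amine or a carboxylic acid on the pyridine ring remains an open case.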